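Moving the Chlorine Around the Phenyl Ring

The source may report more compounds than this note shows. Statements on the series, on what has been measured and on what is new or still open speak of the compounds shown alone.

Going by the values given here, compound 2 `CN1CCN(CCNCc2cn(-c3ccc(F)cc3F)nc2-c2cccc(Cl)c2)CC1` is the only compound here with a definite number in an ADME assay on Huh-7 cells (Homo sapiens) for cytotoxicity; a lower number here means that less compound is tolerated, a higher number that more compound is tolerated: compound 2 gives 15000 nM. Compound 1 `Cc1ccccc1-c1nn(-c2ccc(F)cc2F)cc1CNCCN1CCCCC1` reaches only the limit of the assay, > 20000 nM, in this assay; (the limit of > 20000 nM in this assay, at which 1 of the 2 values shown sits). Compound 3 `CN1CCN(CCNCc2cn(-c3ccc(F)cc3F)nc2-c2ccccc2Cl)CC1` differs from compound 2 in one place: 2-chlorophenyl in place of 3-chlorophenyl on an aromatic carbon. Among the compounds with values here, no step between measured compounds is available for such a change, so no shift beyond the usual scatter is expected in this assay. Compound 3 is therefore estimated to give 15000 nM, within 7000 nM to 30000 nM, an expected step of no change at the digits printed from compound 2 to compound 3 (within the scatter) that is essentially flat.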

Compound 3, half-maximal cytotoxic concentration: > 20000 nM
Compound 3: only a limit was reported; the forecaster's own chance of this, stated with the estimate: 40%; middle value at least 1.3-fold (0.12 log units) away from the limit.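

Moving the chlorine on this aromatic carbon, with 2-chlorophenyl in place of 3-chlorophenyl, gives in this assay an at least 1.3-fold higher number from compound 2 to compound 3 (0.12 log units; that floor lies within the scatter). Going by these compounds alone, this is the first pair here that differs in one place, and it gives no sign that the new chlorine position lowers the number, though a true shift is not established. The value of compound 3 is a limit, so the full size of the step cannot be read: the limit of > 20000 nM in this assay, at which 2 of the 3 values shown sit.

Still open, going by these compounds, is how a plain phenyl or a methoxyphenyl group at this position would compare.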